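Benzyl ester to free acid: one step in the series

The source may hold more compounds than are shown below. What is called first, only, known or untested is meant among the compounds shown, and "the series" means these compounds.

In a functional assay on the whole organism (Tail, strain ICR) with Mus musculus as the target, in the tail flick test, with a stated time of 60 min, at a dose of 12.5 umol/kg by the oral route (on this read-out higher numbers stand for a stronger effect at the one dose given and lower numbers for a weaker effect), compound 1 `NCCCC[C@H](NC(=O)CN(c1nc(Cl)nc2[nH]cnc12)C1CC1)C(=O)OCc1ccccc1` gives 30% and is the compound from which the series is read here. Compound 2 `CC(C)[C@H](NC(=O)CN(c1nc(Cl)nc2[nH]cnc12)C1CC1)C(=O)OCc1ccccc1`, carrying isopropyl in place of 4-aminobutyl on a saturated chain carbon bound to an amide-type nitrogen and a carbonyl carbon, gives 26.5%; the step of a number 3.5 percentage points lower from compound 1 to compound 2 (within the scatter) stays within the scatter. Compound 3 `NCCCC[C@H](NC(=O)CN(c1nc(Cl)nc2[nH]cnc12)C1CC1)C(=O)O` differs from compound 1 by hydrogen in place of benzyl on an oxygen next to a carbonyl group. Among the compounds with values here, no measured step touches this oxygen, so nothing in hand sizes the change; a decrease beyond the scatter is expected, with wide uncertainty, a number 12 percentage points lower from compound 1 to compound 3 (beyond the scatter). Compound 3 is estimated at 18%, between 4% and 40%.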

Compound 3, a percentage reported as activity, at one dose (the size of the read-out at that dose, not a potency): 31.3%
Beside the measured number, compound 3's estimate is 13.3 percentage points below it, within the range that was stated.
By their numbers in this assay, from the lowest: compounds 2, 1 and 3 (each within the scatter of the next).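

Hydrogen in place of benzyl on an oxygen next to a carbonyl group gives a number 1.3 percentage points higher from compound 1 to compound 3 (within the scatter) in this assay, so at this one dose the read-out does not depend on the benzyl group, at least with 4-aminobutyl on the chain. Until now every compound carried benzyloxycarbonyl, so this position had no reading. No evidence in hand bears on why the read-out holds.

From the compounds shown here alone, whether the same change holds with isopropyl on the chain remains open. So does the outcome for a methyl ester or a primary amide at this place.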